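Swapping the aromatic halogen for trifluoromethyl

The source may report more compounds than this note shows. Statements on the series, on what has been measured and on what is new or still open speak of the compounds shown alone.

Compound 1 `COC(=O)[C@@]1(C)CCC=C2[C@@H]1CC[C@@H](C)[C@]2(C)Cc1c(C)[nH]c2ccc(Br)cc12` gives 14000 nM in a functional assay on SW1573 cells (Homo sapiens) for inhibition, read by sulforhodamine B assay, with a stated time of 48 h; on this read-out lower numbers stand for stronger inhibition of growth and higher numbers for weaker inhibition of growth.
Compound 2 `COC(=O)[C@@]1(C)CCC=C2[C@@H]1CC[C@@H](C)[C@]2(C)Cc1c(C)[nH]c2ccc(Cl)cc12` gives 14000 nM in this assay.

Compound 2 stands level with compound 1. Among the compounds with values here, the only measured step, no change at the digits printed from compound 1 to compound 2 (within the scatter), shows that one halogen in place of another left the numbers where they were. Compound 3 `COC(=O)[C@@]1(C)CCC=C2[C@@H]1CC[C@@H](C)[C@]2(C)Cc1c(C)[nH]c2ccc(C(F)(F)F)cc12` differs from compound 2 by trifluoromethyl in place of chloro on an aromatic carbon. Within the data shown here, no measured step bears on this group directly. The expected step is therefore no change at the digits printed from compound 2 to compound 3 (within the scatter), without a direction beyond the scatter. Compound 3 is estimated at 14000 nM, with a range from 5000 nM to 40000 nM.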

Compound 3, concentration for 50% growth inhibition: 15000 nM
Estimate against measurement, compound 3: 1.1-fold (0.03 log units) below; the measured number falls inside the stated range.
By their numbers in this assay, from the lowest: compounds 1, 2 and 3 (each within the scatter of the next).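

In this assay, the step to trifluoromethyl gives a 1.1-fold higher number from compound 2 to compound 3 (0.03 log units; within the scatter) and, against bromo, a 1.1-fold higher number from compound 1 to compound 3 (0.03 log units; within the scatter). The halogen swap alone compared only single atoms, whereas this aromatic carbon now carries a group of 4 heavy atoms in place of 1 and the numbers still stay level. Nothing available here explains this level reading. The compounds shown leave open whether an amine, a carboxylic acid or a longer chain on this carbon would move the number beyond the scatter.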